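From 4-acetylphenyl to cyclopropyl on the shared core

The compounds below may be only part of what the source reports. "The series", "measured", "known", "first", "only" and "open" are said of these compounds alone.

Compound 1 (`O=C(Nc1ccccn1)c1cc(=O)[nH]c2cc(Br)ccc12`) gives 11000 nM
Compound 2 (`O=C(Nc1cc(F)cc(F)c1)c1cc(=O)[nH]c2cc(Cl)ccc12`) gives 9000 nM
Compound 3 (`CC(=O)c1ccc(-c2ccc3c(C(=O)Nc4cccc(F)c4)cc(=O)[nH]c3c2)cc1`) gives > 20000 nM as a limit

All three readings come from a functional assay on KYSE-70 cells for antiproliferative activity against KYSE-70 cell line (Homo sapiens), read by MTT assay, with a stated time of 72 h (on this read-out lower numbers stand for stronger inhibition and higher numbers for weaker inhibition), and compound 4 (`O=C(Nc1cccc(F)c1)c1cc(=O)[nH]c2cc(C3CC3)ccc12`) has yet to be measured there.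

Compound 3 stands at > 20000 nM as a limit of the assay and not as a number.

The change leading to compound 4 is cyclopropyl in place of 4-acetylphenyl on an aromatic carbon so that cyclopropyl takes the place of 4-acetylphenyl on an aromatic carbon of the shared core. Going by the values given here, no measured pair of compounds differing in one place is available to size this change. Compound 1 reads 11000 nM in this assay and compound 2 reads 9000 nM there, and neither carries a 4-acetylphenyl, though both also differ from compound 4 elsewhere. Among the compounds with values here, these two readings lie within the usual scatter of each other, and they are the only numbers on which an expectation can rest.

The expected change is an at least 2.0-fold lower number from compound 3 to compound 4 (0.30 log units; that floor lies within the scatter) in the direction of stronger inhibition, an estimate of modest size that would go unseen if the assay again reported only a limit. For compound 4 the estimated value is 10000 nM with an expected range from 4000 nM to 20000 nM in this measurement.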

Compound 4, half-maximal inhibitory concentration: > 20000 nM
Compound 4: only a limit was reported (the forecaster's own chance of this, stated with the estimate: 20%); middle value at least 2.0-fold (0.30 log units) from the limit.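

Compound 3 and compound 4 are each reported only as a limit and not as a number, so no step between them can be read: the limit of > 20000 nM in this assay, at which 2 of the 4 values shown sit.

The compounds shown leave open what number either compound would give, and whether cyclopropyl in place of 4-acetylphenyl on an aromatic carbon of the shared core changes the read-out at all.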